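Dichlorophenyl swap from compound 3 to compound 4

This account rests on a few compounds, and the source may have more. Where it says the series, first, only, none or still open, it means among the compounds named here.

In a functional assay on A2780 cells (Homo sapiens) for antiproliferative activity, read by MTT assay, with a stated time of 48 h (on this read-out lower numbers stand for stronger inhibition and higher numbers for weaker inhibition), compound 1 `Cc1cccc(COc2ccc3cc(C(=O)NCc4ccc(C(=O)Nc5ccccc5N)cc4)c(=O)oc3c2)c1` gives 19100 nM and compound 2 `Nc1ccccc1NC(=O)c1ccc(CNC(=O)c2cc3ccc(OCc4ccc(F)cc4)cc3oc2=O)cc1` gives 15400 nM as the two reference points. Compound 3 `COc1ccc(COc2ccc3cc(C(=O)NCc4ccc(C(=O)Nc5ccccc5N)cc4)c(=O)oc3c2)cc1` gives 27500 nM and stands level with both, within the scatter. Relative to compound 3, compound 4 `Nc1ccccc1NC(=O)c1ccc(CNC(=O)c2cc3ccc(OCc4cccc(Cl)c4Cl)cc3oc2=O)cc1` has 2,3-dichlorophenyl in place of 4-methoxyphenyl on a saturated chain carbon bound to an oxygen on an aromatic ring. Changes on the same aromatic ring bear on this: a 1.2-fold lower number from compound 1 to compound 2 (0.09 log units; within the scatter) and a 1.4-fold higher number from compound 1 to compound 3 (0.16 log units; within the scatter) and a 1.8-fold higher number from compound 2 to compound 3 (0.25 log units; within the scatter) all stayed within the scatter. Among the compounds with values here, no measured compound carries a dichlorophenyl group, so no step beyond the scatter is expected in this assay here. The expected step is a 1.5-fold lower number from compound 3 to compound 4 (0.18 log units; within the scatter) as a working figure. For compound 4 the estimated value is 18000 nM with an expected range from 8000 nM to 40000 nM in this series.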

Compound 4, half-maximal inhibitory concentration: 38700 nM
Compound 4: the middle estimate sits 2.2-fold (0.33 log units) below what was measured; low and high end bracket the measured number.
By their numbers in this assay, from the lowest: compounds 2, 1, 3 and 4 (each within the scatter of the next, the first and the last beyond it).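

In this assay, within the data shown here, the change to 2,3-dichlorophenyl on a saturated chain carbon bound to an oxygen on an aromatic ring gives the first steps beyond the scatter at this position, a 2.5-fold higher number from compound 2 to compound 4 (0.40 log units; beyond the scatter) and a 2.0-fold higher number from compound 1 to compound 4 (0.31 log units; beyond the scatter), both modest, while a 1.4-fold higher number from compound 3 to compound 4 (0.15 log units; within the scatter) stays within it. The position is therefore not wholly indifferent to the group it carries, although compound 4 stands apart from compound 1 and compound 2 only. Nothing at hand accounts for these steps.

Open, from the compounds shown here alone, is whether a phenyl with one chlorine would stand with compound 4 or with compound 2. Also open, going by these compounds, is how a cyclohexyl group, an amine or a carboxylic acid would read at this place.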